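The source may report more compounds than this note shows. Statements on the series, on what has been measured and on what is new or still open speak of the compounds shown alone.

Four compounds share a cinnamate ester built on a phenol ring, and they differ in the ester portion and in one substituent on that ring. Compound 2 `O=C(/C=C/c1ccc(O)c(O)c1)OCc1c(-c2ccccc2)no[n+]1[O-]` and compound 3 `COc1cc(/C=C/C(=O)OCc2c(-c3ccccc3)no[n+]2[O-])ccc1O` carry the same ester group; compound 1 `O=C(/C=C/c1ccc(OCCCCO[N+](=O)[O-])c(O)c1)OCCCCO[N+](=O)[O-]` and compound 4 `COc1cc(/C=C/C(=O)OCCCCO[N+](=O)[O-])ccc1OCCCCO[N+](=O)[O-]` carry another. The difference between the core of compound 1 and that of compound 2 is not broken down here.

In a functional assay on M14 cells (Homo sapiens) for cytotoxicity, read by resazurin assay, with a stated time of 72 h (a higher number here means a weaker inhibitor, a lower number a stronger inhibitor), compound 2 gives 12500 nM. In this assay compound 3 gives 14000 nM. The change from compound 2 to compound 3 is methyl in place of hydrogen on an oxygen on an aromatic ring and it made a 1.1-fold higher number from compound 2 to compound 3 (0.05 log units; within the scatter), so the two values are within the usual scatter of each other.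

For compound 1 only a limit is known: in this assay compound 1 gives > 50000 nM. It is the one value among these that sits at the limit of > 50000 nM in this assay, at which 1 of the 3 values shown sits, meaning no number below that limit was obtained.

Compound 4 is obtained from compound 1 by methyl in place of hydrogen on an oxygen on an aromatic ring, the same change that turns compound 2 into compound 3. Since that change left the value of compound 3 within the scatter of compound 2, as a 1.1-fold higher number from compound 2 to compound 3 (0.05 log units; within the scatter) shows, the step that the limit leaves unreadable from compound 1 to compound 4 is expected to be equally small. Because compound 1 itself gave only > 50000 nM, compound 4 is expected to land around 80000 nM, probably again reported only as a limit, with a plausible range from 30000 nM to 250000 nM.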

Compound 4, half-maximal inhibitory concentration: > 50000 nM
Compound 4: no number, only a limit (the forecaster's own chance of this, stated with the estimate: 75%); the middle value lies beyond the limit too.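

Compound 1 and compound 4 both end at a limit in this assay rather than at a number, so the size of the step between them cannot be read: the limit of > 50000 nM in this assay, at which 2 of the 4 values shown sit.

Still open, from the compounds shown here alone, is whether methyl in place of hydrogen changes as little on the core of compound 1 as between compound 2 and compound 3, and what real values compound 1 and compound 4 have.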